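Swapping bromo for trifluoromethyl: what to expect

The compounds below may be only part of what the source reports. "The series", "measured", "known", "first", "only" and "open" are said of these compounds alone.

Of the compounds shown here, three sharing one core have been measured in an ADME assay on cells (Hepatocyte, Mus musculus) for cytotoxicity, read by MTT assay, with a stated time of 24 h; a higher number here means that more compound is tolerated, a lower number that less compound is tolerated. Compound 1 `COc1ccc(S(=O)(=O)n2c(-c3cn(-c4ccccc4)nc3-c3ccc(C(F)(F)F)cc3)nc3ccccc32)cc1` gives 87400 nM, compound 2 `Cc1ccc(C)c(S(=O)(=O)n2c(-c3cn(-c4ccccc4)nc3-c3ccc(C(F)(F)F)cc3)nc3ccccc32)c1` gives 132000 nM, and compound 3 `O=S(=O)(c1ccc(Br)cc1)n1c(-c2cn(-c3ccccc3)nc2-c2ccc(C(F)(F)F)cc2)nc2ccccc21` gives 167000 nM. These numbers all lie within the usual scatter of one another, so compound 3 does not stand apart from the other two.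

Compound 4 `O=S(=O)(c1ccc(C(F)(F)F)cc1)n1c(-c2cn(-c3ccccc3)nc2-c2ccc(C(F)(F)F)cc2)nc2ccccc21` differs from compound 3 in one place, with trifluoromethyl in place of bromo on an aromatic carbon, para to a large group: trifluoromethyl in place of bromo on an aromatic carbon. The nearest evidence comes from changes on the same sulfonyl side. The data show a 1.9-fold higher number from compound 1 to compound 3 (0.28 log units; within the scatter) and a 1.3-fold higher number from compound 2 to compound 3 (0.10 log units; within the scatter), and a 1.5-fold higher number from compound 1 to compound 2 (0.18 log units; within the scatter) as well. All three steps stay within the scatter, but none of them involves trifluoromethyl. A step beyond the scatter is therefore not expected, and no direction can be favoured. The expected step is a 1.2-fold lower number from compound 3 to compound 4 (0.08 log units; within the scatter). For compound 4 the estimated value is 140000 nM, with an expected range from 75000 nM to 260000 nM.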

Compound 4, half-maximal cytotoxic concentration: 137000 nM
For compound 4 the middle estimate is 1.0-fold (0.01 log units) above the measured one; measured number inside the range.
By their numbers in this assay, from the lowest: compounds 1, 2, 4 and 3 (each within the scatter of the next).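

Going from bromo, with one heavy atom, to trifluoromethyl, with four, on an aromatic carbon para to a large group does not move the number in this assay beyond the scatter: the data give a 1.2-fold lower number from compound 3 to compound 4 (0.09 log units; within the scatter). The other two comparisons read the same way, with a 1.0-fold higher number from compound 2 to compound 4 (0.02 log units; within the scatter) and a 1.6-fold higher number from compound 1 to compound 4 (0.20 log units; within the scatter), so all four aryl groups on the sulfonyl sulfur now lie within the scatter of one another, and a larger group at this place has shown no measurable cost here. Nothing shown speaks to the reason for this flat picture.

Still open, from the compounds shown here alone, is whether a group of another kind on this ring, such as an amine or a carboxylic acid, would give a step beyond the scatter. Also open, going by these compounds, is whether the picture holds when the shared core itself changes, as all four compounds carry it unchanged.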